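Swapping methoxy for chloro on a hemolysis read-out

The source may report more compounds than this note shows. Statements on the series, on what has been measured and on what is new or still open speak of the compounds shown alone.

Measured so far:
Compound 1, `N=C(N)c1ccc(-c2ccc(-c3cc(Cl)cc(Cl)c3)s2)s1`: 17%
Compound 2, `COc1ccc(-c2ccc(-c3ccc(C(=N)N)o3)o2)cc1`: 71.7%
Compound 3, `N=C(N)c1ccc(-c2ccc(-c3ccccc3)s2)s1`: 85.1%

The three compounds were tested in an ADME assay on cells (Erythrocyte, Homo sapiens) for activation, read by hemolysis, with a stated time of 30 min, tested at 10 mM; on this read-out higher numbers stand for a stronger effect at the one concentration tested and lower numbers for a weaker effect. Compound 1 gives 17%, compound 2 gives 71.7%, and compound 3 gives 85.1%. Compound 2 stands second highest of the three numbers: compound 3 is its nearest neighbour, beyond the scatter, and compound 1 lies furthest from it, also beyond the scatter.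

The next compound, compound 4, `N=C(N)c1ccc(-c2ccc(-c3ccc(Cl)cc3)o2)o1`, is not yet measured. It differs from compound 2 in one place: chloro in place of methoxy on an aromatic carbon. For the measured compounds named here, no step between two measured compounds tells how such a change plays out, so the expectation rests on the spread of the three values. A moderate downward step in this assay is expected, though one that could also fall within the scatter. The expected step of a number 16.7 percentage points lower from compound 2 to compound 4 (beyond the scatter) leads to an estimate for compound 4 of 55%, with a range from 25% to 85%.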

Compound 4, a percentage reported as activity, at one concentration (the size of the read-out at that concentration, not a potency): 97.3%
The estimate for compound 4 lay 42.3 percentage points below the measured number; the measured number lies above the stated range.
By their numbers in this assay, from the lowest: compound 1; then compound 2; then compound 3; then compound 4.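

For the compounds shown here, the first comparison in one place comes from chloro in place of methoxy, on an aromatic carbon of a six-membered aromatic ring of carbon only, para to a large group: in this assay it gives a number 25.6 percentage points higher from compound 2 to compound 4 (beyond the scatter) at the one concentration tested. The read-out therefore responds to what sits at this position, and here the group with fewer heavy atoms and no hydrogen-bond acceptor goes with the stronger effect. Nothing at hand explains the rise, so it stands as an observation only.

This single pair cannot separate what chloro adds from what the loss of methoxy removes. An amine, a carboxylic acid or a longer chain on the same carbon would show how far the number moves with other groups there.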